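A Chlorine Moves Round the Anilino Ring

A few compounds are considered here, and "the series" means these few. Any claim that something is new, unique, unknown or untested is made for them only; others in the source may bear on it.

Compound 1 `FC(F)(F)c1ccc(CSc2nc(Nc3ccccc3)c3ccccc3n2)cc1` was tested in a functional assay on MDA-MB-231 cells (Homo sapiens) for cytotoxicity, read by MTT assay, with a stated time of 72 h (a higher number here means a weaker inhibitor, a lower number a stronger inhibitor), where compound 1 gives 18400 nM. Among the measured compounds shown here, of the two numbers measured so far this is the higher one, yet the gap to its only neighbour lies within the usual scatter, so the two compounds cannot be told apart. That neighbour, compound 2 `FC(F)(F)c1ccc(CSc2nc(Nc3cccc(Cl)c3)c3ccccc3n2)cc1`, gives 18000 nM in this assay. For the measured compounds named here, the one measured step, a 1.0-fold lower number from compound 1 to compound 2 (0.01 log units; within the scatter), put chloro in place of hydrogen on an aromatic carbon and left the number where it was.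

Compound 3 `FC(F)(F)c1ccc(CSc2nc(Nc3ccc(Cl)cc3)c3ccccc3n2)cc1` has not yet been measured. It differs from compound 1 by chloro in place of hydrogen on an aromatic carbon, the same kind of swap as before, only at another carbon of the same ring. Going by the values given here, since the single comparable step showed no shift, the expectation is that this one will show none beyond the scatter either, with a 1.1-fold lower number from compound 1 to compound 3 (0.03 log units; within the scatter) as the estimated step. For compound 3 in this assay the estimate is 17000 nM, with a range from 8000 nM to 40000 nM.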

Compound 3, half-maximal inhibitory concentration: 15100 nM
Compound 3: middle estimate off by 1.1-fold (0.05 log units), on the high side, within the range that was stated.
By their numbers in this assay, from the lowest: compounds 3, 2 and 1 (each within the scatter of the next).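

Compound 3 gives the ring a second chlorine position to compare, on the carbon para to a large group. In this assay, adding chloro there produces a step (a 1.2-fold lower number from compound 1 to compound 3 (0.09 log units; within the scatter)) no larger than repeat measurements can produce by chance, so neither chlorine position has yet separated itself from the unsubstituted phenyl group of compound 1. The new comparison that compound 3 allows is a direct one, in which the chlorine changes position while everything else stays the same (a 1.2-fold lower number from compound 2 to compound 3 (0.08 log units; within the scatter)), and it shows that the 3-chlorophenyl and 4-chlorophenyl versions cannot be told apart in this test, while no measurement at hand offers an explanation for this flat response.

As far as these compounds go, these compounds tested only chlorine on this ring, so it remains open whether a different group there, such as an amine, a carboxylic acid or a longer chain, would shift the number beyond the scatter. From the compounds shown here alone, it is also open whether a change elsewhere in the molecule, such as a nitrile in place of the trifluoromethyl group, would have a larger effect than any seen here.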